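Removing a Small Side Chain from Compound 2

The source may report more compounds than this note shows. Statements on the series, on what has been measured and on what is new or still open speak of the compounds shown alone.

Compound 1 `O=C1O[C@H]([C@@H](O)Cn2cc(CNS(=O)(=O)c3ccc(Cl)cc3F)nn2)C(OCc2ccccc2)=C1OCc1ccccc1` gives 39100 nM in a functional assay on A549 cells (Homo sapiens) for antiproliferative activity, read by MTT assay, with a stated time of 72 h; on this read-out higher numbers stand for weaker inhibition and lower numbers for stronger inhibition.
Compound 2 `O=C1O[C@H]([C@@H](O)Cn2cc(CCO)nn2)C(OCc2ccccc2)=C1OCc1ccccc1` gives > 100000 nM in this assay.
Compound 3 `COc1ccccc1-c1cn(C/C=C2\OC(=O)C(OCc3ccccc3)=C2OCc2ccccc2)nn1` gives > 100000 nM in this assay.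

The value of compound 2 is not a number but a limit of this assay, namely (the limit of > 100000 nM in this assay, at which 2 of the 3 values shown sit). Compound 2 therefore stands at the weak end of what was measured. Within the data shown here, the one measured step that touches its side chain is an at least 2.5-fold higher number from compound 1 to compound 2 (0.40 log units; beyond the scatter), which shows that exchanging the group on that chain can move the number. Compound 4 `O=C1O[C@H]([C@@H](O)Cn2ccnn2)C(OCc2ccccc2)=C1OCc1ccccc1` goes one step further: hydrogen in place of 2-hydroxyethyl on an aromatic carbon. Among the measured compounds shown here, no measured pair covers this exact removal, so the expectation rests on where compound 2 sits. Since compound 2 already sits at the limit (the limit of > 100000 nM in this assay, at which 2 of the 3 values shown sit), a step beyond the scatter in either direction would be hard to see, and none is expected; compound 4 is expected to stay at the limit, with a number no higher from compound 2 to compound 4 (the limit leaves the size open). Compound 4 is estimated at 100000 nM, in the range 30000 nM to 300000 nM.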

Compound 4, half-maximal inhibitory concentration: > 100000 nM
Compound 4: a limit, no number; the forecaster's own chance of this, stated with the estimate: 80%; the middle value sits exactly at the limit.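

No step can be read from compound 2 to compound 4, because each gives a limit of the assay rather than a number: the limit of > 100000 nM in this assay, at which 3 of the 4 values shown sit. The compounds shown leave open whether hydrogen in place of 2-hydroxyethyl changes the result in this assay at all, and in which direction.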